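Replacing the aryl group of compound 1 with 3-hydroxyphenyl

A few compounds are considered here, and "the series" means these few. Any claim that something is new, unique, unknown or untested is made for them only; others in the source may bear on it.

In a functional assay on HCC827 cells (Homo sapiens) for inhibition, read by fluorescence, with a stated time of 72 h (a lower number here means a stronger inhibitor of growth, a higher number a weaker inhibitor of growth), compound 1 `COc1ccc(Nc2nc(N[C@H]3CC[C@H](N)CC3)nc3c2ncn3CCC(C)C)c(OC)c1` gives 32900 nM and stands at the high end of the measured numbers. Compound 3 `CCCCCCn1cnc2c(Nc3ccc(O)cc3)nc(N[C@H]3CC[C@H](N)CC3)nc21` gives 24700 nM and is within the scatter of compound 1. Compound 2 `CC(C)=CCn1cnc2c(Nc3cccc(Cl)c3)nc(N[C@H]3CC[C@H](N)CC3)nc21` gives 13500 nM and lies below compound 1 by more than the scatter. Compound 4 `CC(C)CCn1cnc2c(Nc3cccc(O)c3)nc(N[C@H]3CC[C@H](N)CC3)nc21` is the next to be read, and the change is 3-hydroxyphenyl in place of 2,4-dimethoxyphenyl on a nitrogen on an aromatic ring with 3-hydroxyphenyl in place of 2,4-dimethoxyphenyl on a nitrogen on an aromatic ring. Within the data shown here, no two measured compounds differ in one place only, so the guide is indirect. Compound 3 also has a hydroxy-bearing phenyl on that nitrogen and sits at 24700 nM in the same range. The step expected in this assay is a 1.8-fold lower number from compound 1 to compound 4 (0.26 log units; within the scatter) and leans to a lower number while staying within the scatter. Compound 4 is estimated at 18000 nM with an expected range from 6000 nM to 50000 nM in this series.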

Compound 4, concentration for 50% growth inhibition: 21300 nM
The estimate for compound 4 lay 1.2-fold (0.07 log units) below the measured number, within the range that was stated.
By their numbers in this assay, from the lowest: compounds 2, 4, 3 and 1 (each within the scatter of the next, the first and the last beyond it).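

In this assay, among these compounds, 3-hydroxyphenyl in place of 2,4-dimethoxyphenyl on a nitrogen on an aromatic ring gives a 1.5-fold lower number from compound 1 to compound 4 (0.19 log units; within the scatter) and provides the first single-place comparison. Exchanging a group without a hydrogen-bond donor for a smaller one with a hydrogen-bond donor therefore does not separate the two compounds beyond the scatter. No evidence on hand bears on this result.

On these data alone, whether an aminophenyl group on that nitrogen would separate from compound 4 remains open. Also open, as far as these compounds go, is whether a carboxylic acid on that aromatic ring would do so.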